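Ethyl to methyl on the core of compound 3

The source may report more compounds than this note shows. Statements on the series, on what has been measured and on what is new or still open speak of the compounds shown alone.

Compound 1, `CC(C(=O)N1CCN(c2ccc(C(F)(F)F)cc2)CC1)N1C(=O)CCC1=O`, gives 25% in a functional assay on the whole organism (strain Swiss) with Mus musculus as the target, in the maximal electroshock model, with a stated time of 0.25 h, at a dose of 300 mg/kg by the intraperitoneal route; a higher number here means a stronger effect of the compound at the dose given, a lower number a weaker effect.
Compound 2, `CCC(C(=O)N1CCN(c2ccc(C(F)(F)F)cc2)CC1)N1C(=O)CCC1=O`, gives 25% in this assay.
Compound 3, `CCC(C(=O)N1CCN(c2ccc(F)cc2)CC1)N1C(=O)CCC1=O`, gives 0% in this assay.

Compound 4, `CC(C(=O)N1CCN(c2ccc(F)cc2)CC1)N1C(=O)CCC1=O`, has not yet been measured. It differs from compound 3 by one change, (hydrogen in place of methyl on a saturated chain carbon, two bonds along the chain from an amide-type nitrogen in a ring and a carbonyl carbon). The same change has already been made once among the measured compounds, from compound 2 to compound 1: hydrogen in place of methyl on a saturated chain carbon, two bonds along the chain from an amide-type nitrogen in a ring and a carbonyl carbon. There it made no change at the digits printed from compound 2 to compound 1 (within the scatter). The core on which the new change is made is not the same as the one on which the earlier change was made; the two cores differ by fluoro in place of trifluoromethyl on an aromatic carbon, and that difference made a number 25 percentage points lower from compound 2 to compound 3 (beyond the scatter), leaving compound 3 with the lowest number of the three.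

For compound 4 the step is expected to be no change at the digits printed from compound 3 to compound 4 (within the scatter), much like the earlier one, because the same change from compound 2 to compound 1 gave no change at the digits printed from compound 2 to compound 1 (within the scatter) and because compound 3 itself gives 0%, which leaves little room for a fall. Compound 4 is therefore estimated at 0% in this assay, expected to lie between 0% and 12%.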

Compound 4, a percentage reported as activity, at one dose (the size of the read-out at that dose, not a potency): 100%
For compound 4 the middle estimate is 100 percentage points below the measured one, outside the stated range (above it).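

In this assay, ethyl to methyl gives a number 100 percentage points higher from compound 3 to compound 4 (beyond the scatter), so this change does not carry over unaltered from the trifluoromethyl core to the fluoro core: the same change on two cores in this assay, no change at the digits printed (within the scatter) from compound 2 to compound 1 and a number 100 percentage points higher (beyond the scatter) from compound 3 to compound 4, 100 percentage points apart, beyond the scatter of two such steps. The swap on the aromatic carbon also depends on the chain, with fluoro in place of trifluoromethyl giving a number 75 percentage points higher from compound 1 to compound 4 (beyond the scatter) on the methyl side, whereas it lowered the number on the ethyl side: the same change on two cores in this assay, a number 25 percentage points lower (beyond the scatter) from compound 2 to compound 3 and a number 75 percentage points higher (beyond the scatter) from compound 1 to compound 4, 100 percentage points apart, beyond the scatter of two such steps. Across these four compounds, the two changes therefore do not act independently, as the result of each depends on the other, but this does not explain why, nor does it set a rule for the series, as each number comes from a single dose and time.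

The compounds shown leave open whether the same dependence would appear with a longer chain, such as propyl, or with a chloro group on the aromatic carbon. They also leave open how strong the effect of compound 4 would be at lower doses.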